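Ethynyl for cyano: two measured compounds, one pending

The compounds below may be only part of what the source reports. "The series", "measured", "known", "first", "only" and "open" are said of these compounds alone.

Measured so far in a functional assay on MCF7 cells (Homo sapiens) for inhibition, with a stated time of 72 h; a higher number here means a weaker inhibitor of growth, a lower number a stronger inhibitor of growth:
compound 1 `C[Si](C)(C)C#Cc1cc(-c2nc3cc(F)ccc3s2)ccc1N` gives 160 nM
compound 2 `N#Cc1cc(-c2nc3c(F)cccc3s2)ccc1N` gives 180 nM

In this assay compound 2 gives 180 nM and compound 1 gives 160 nM; the two numbers lie within the scatter of each other, so neither compound is set apart by the data so far. Compound 3 `C#Cc1cc(-c2nc3c(F)cccc3s2)ccc1N` is not yet measured. It differs from compound 2 by ethynyl in place of cyano on an aromatic carbon. Among the compounds with values here, no step between measured compounds isolates this change, and compound 1 differs from compound 2 in more than one place, so its value cannot be carried over to the question. The expectation is therefore no step beyond the scatter, in either direction, from compound 2 to compound 3, and the estimated step is a 1.1-fold higher number from compound 2 to compound 3 (0.05 log units; within the scatter). For compound 3 the expected value in this assay is 200 nM, with a range from 60 nM to 700 nM, the width reflecting the absence of a matched comparison.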

Compound 3, concentration for 50% growth inhibition: 110 nM
Estimate against measurement, compound 3: 1.8-fold (0.26 log units) above; the range from low to high includes it.
By their numbers in this assay, from the lowest: compounds 3, 1 and 2 (each within the scatter of the next).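

Within the data shown here, the step of a 1.6-fold lower number from compound 2 to compound 3 (0.21 log units; within the scatter) in this assay is the first matched comparison, and it isolates this one change on an aromatic carbon ortho to an amino group and meta to a large group. At this position, ethynyl, counted with 0 hydrogen-bond acceptors, replaces cyano, counted with 1 hydrogen-bond acceptor, and the step stays within the scatter, so the data do not separate the two groups. No measurement available here offers an explanation for this result.

Open, on these data alone, is what a group of a different kind at this place, such as an amine, a carboxylic acid or a longer chain, would give in this assay. Also open, as far as these compounds go, is whether ethynyl in place of cyano gives a similar step on the core of compound 1.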